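The compounds below may be only part of what the source reports. "The series", "measured", "known", "first", "only" and "open" are said of these compounds alone.

Measured so far:
- compound 1 `Cc1cc(NC(=O)Nc2cccc(Cl)c2Cl)ccc1-n1ccc2c(NC(=O)c3ccccc3)nccc21` — > 10000 nM
- compound 2 `O=C(Nc1ccc(-n2ccc3c(NC(=O)c4ccccc4)nccc32)cc1)c1cccc(C(F)(F)F)c1` — 100 nM

Two compounds have been run in a functional assay on A-375 cells (Homo sapiens) for antiproliferative activity, read by MTT assay, with a stated time of 48 h, in the presence of a further agent that is not named here; on this read-out higher numbers stand for weaker inhibition and lower numbers for stronger inhibition. For compound 1 the value > 10000 nM is a limit of the assay, not a number. Going by the values given here, compound 2 therefore holds the only number in this assay, at 100 nM; the other entry sits at the limit of > 10000 nM in this assay, at which 1 of the 2 values shown sits. Among the compounds with values here, compound 1 and compound 2 differ in more than one place, so no single step between them can be read.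

Compound 3 `Cc1cc(NC(=O)c2cccc(C(F)(F)F)c2)ccc1-n1ccc2c(NC(=O)c3ccccc3)nccc21` is the next candidate. From compound 2 it differs by methyl in place of hydrogen on an aromatic carbon. Within the data shown here, no measured step isolates this change, so its size can only be guessed. Compound 1, which carries the same methyl with a different linker, gives only a limit, which leaves the question open. A modest loss beyond the scatter is expected: the estimated step is a 3.0-fold higher number from compound 2 to compound 3 (0.48 log units; beyond the scatter). Compound 3 is expected near 300 nM, within a range from 60 nM to 3000 nM.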

Compound 3, half-maximal inhibitory concentration: > 10000 nM
Compound 3: a limit, no number (the forecaster's own chance of this, stated with the estimate: 15%); at least 33-fold (1.52 log units) between middle value and limit.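

In this assay, going by these compounds alone, the single change of methyl in place of hydrogen on an aromatic carbon, ortho to a large group and meta to a large group, gives an at least 100-fold higher number from compound 2 to compound 3 (2.00 log units; beyond the scatter): this is the first readable step, and it is large for one added carbon. The value of compound 3 is a limit and not a number, so the step has only a lower bound, and the step between compound 1 and compound 3 cannot be read. Of the compounds shown, only compound 2, without this methyl, holds a number: the limit of > 10000 nM in this assay, at which 2 of the 3 values shown sit.

As far as these compounds go, whether a fluorine atom, a methoxy group or an ethyl group on the same carbon would keep a number stays open. Also open, from the compounds shown here alone, is whether the linker of compound 1 gives a number with hydrogen in place of the methyl.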